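From 3-cyanophenyl to 4-vinylphenyl at the assay limit

The compounds below may be only part of what the source reports. "The series", "measured", "known", "first", "only" and "open" are said of these compounds alone.

In a functional assay on B16-F0 cells (Mus musculus) for inhibition, read by CCK-8 assay, with a stated time of 48 h (a lower number here means a stronger inhibitor, a higher number a weaker inhibitor), each value below is a limit of the assay:
Compound 1 `COc1cc(-c2cc3nccc(-c4cc(OC)c(OC)c(OC)c4)n3n2)cc(OC)c1OC` gives > 10000 nM as a limit
Compound 2 `COc1cc(-c2cc3nccc(-c4c[nH]c5ccccc45)n3n2)cc(OC)c1OC` gives > 10000 nM as a limit
Compound 3 `COc1cc(-c2ccnc3cc(-c4cccc(C#N)c4)nn23)cc(OC)c1OC` gives > 10000 nM as a limit

Compound 3 stands with > 10000 nM as its reading in this assay and that reading is a limit, not a number. Among the measured compounds shown here, the other two compounds sit in the same place, so the series so far is the limit of > 10000 nM in this assay, at which 3 of the 3 values shown sit, with no graded value among them.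

Compound 4 `C=Cc1ccc(-c2cc3nccc(-c4cc(OC)c(OC)c(OC)c4)n3n2)cc1` has not yet been measured. It carries 4-vinylphenyl in place of 3-cyanophenyl on an aromatic carbon and is otherwise the same as compound 3.

No measured step among these compounds shows what such a swap does. The expectation rests on compound 3 reading > 10000 nM as a limit, so no large gain is foreseen. A small shift toward stronger inhibition is expected, estimated as an at least 1.2-fold lower number from compound 3 to compound 4 (0.09 log units; that floor lies within the scatter) in this read-out, and another limit reading is about as likely as a number. Compound 4 is expected at an estimated 8000 nM with an expected range from 1500 nM to 20000 nM for the measurement.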

Compound 4, half-maximal inhibitory concentration: 788 nM
Estimate against measurement, compound 4: 10-fold (1.01 log units) above, outside the stated range (below it).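

On an aromatic carbon of the five-membered ring, placing 4-vinylphenyl in place of 3-cyanophenyl gives, in this assay, an at least 12-fold lower number from compound 3 to compound 4 (1.10 log units; beyond the scatter), so a substituent at this place can bring a graded reading. On these data alone, compound 3 reads > 10000 nM, which is a limit, so the step sets only a floor and its true size stays unknown. Compound 4 holds the only graded value among the compounds shown, and the others stay at one limit: the limit of > 10000 nM in this assay, at which 3 of the 4 values shown sit.

The single swap removes the nitrile and adds the vinyl group together, so the compounds shown cannot tell which of the two matters. As far as these compounds go, it also remains open whether an unsubstituted phenyl, a 4-ethylphenyl or a phenyl bearing an amine at this place would keep a graded reading.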